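The source may report more compounds than this note shows. Statements on the series, on what has been measured and on what is new or still open speak of the compounds shown alone.

Of the compounds shown here, three built on one shared core have been tested in an ADME assay for metabolic stability, read by LC-MS, with a stated time of 3 h, at pH 6.5, tested at 50 uM; on this read-out higher numbers stand for a more stable compound and lower numbers for a less stable compound. Compound 1, `C[C@@H](O)[C@H]1C(=O)N2C3=C(S[C@@H]4CN[C@@H](C4)C(=O)Nc4cccc(c4)C(=O)OCCCCOC3=O)[C@H](C)[C@H]12`, stands at the limit of the assay: compound 1 gives > 95%, which is a limit rather than a number. Compound 2, `CC(C)OC(=O)OCOC(=O)C1=C(S[C@@H]2CN[C@H](C(=O)Nc3cccc(C(=O)OCOC(=O)OC(C)C)c3)C2)[C@H](C)[C@@H]2[C@@H]([C@@H](C)O)C(=O)N12`, also sits at that limit, as compound 2 gives > 95%. Compound 3, `CCCCCCCCCCCCCCCCOC(=O)C1=C(S[C@@H]2CN[C@H](C(=O)Nc3cccc(C(=O)OCCCCCCCCCCCCCCCC)c3)C2)[C@H](C)[C@@H]2[C@@H]([C@@H](C)O)C(=O)N12`, does the same, and compound 3 gives > 95%. On the numbers shown, compound 2 therefore stands where every measured compound stands, at the limit of > 95% in this assay, at which 3 of the 3 values shown sit, and nothing separates the three.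

Compound 4, `CC(C)OC(=O)OCOC(=O)C1=C(S[C@@H]2CN[C@H](C(=O)Nc3cccc(C(=O)O)c3)C2)[C@H](C)[C@@H]2[C@@H]([C@@H](C)O)C(=O)N12`, remains to be measured. It differs from compound 2 in one place: hydrogen in place of ((isopropoxycarbonyl)oxy)methyl on an oxygen next to a carbonyl group. For the measured compounds named here, no step between two measured compounds has been determined, so there is no measured step to draw on, and the change is expected to bring either no shift beyond the usual scatter or a modest drop. Compound 4 is expected to give 92%, in a range from 75% to 98%. That estimate means an expected step of a number at least 3 percentage points lower from compound 2 to compound 4 (that floor lies within the scatter), which stays within the scatter.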

Compound 4, percent of the compound remaining: > 95%
Compound 4 was reported as a limit (the forecaster's own chance of this, stated with the estimate: 55%); at least 3 percentage points between middle value and limit.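

In this assay compound 4 gives > 95%, which is a limit and not a number. Compound 2 also sits at a limit, and no step can be read between compound 2 and compound 4. The compounds shown leave open whether hydrogen in place of ((isopropoxycarbonyl)oxy)methyl changes the percent remaining at all.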